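This account rests on a few compounds, and the source may have more. Where it says the series, first, only, none or still open, it means among the compounds named here.

Series notes on the adenosine receptor work. Three compounds carry numbers in an assay on membranes from CHO cells for displacement of a labelled ligand from adenosine receptor A1 (Homo sapiens), read by scintillation counting, with a stated time of 60 min, tested at 1 uM; a lower number here means less inhibition, a higher number more inhibition at the concentration tested (going by the name of the read-out). Compound 1 `CC1=C(C(=O)OCC(C)C)C(c2ccco2)NC(=S)N1` gives 7% in this assay. Compound 2 `CC1=C(C(=O)OC(C)(C)C)C(c2ccoc2)NC(=O)N1C` gives 21% in this assay. Compound 3 `CC1=C(C(=O)C2CC2)C(c2ccco2)NC(=O)N1` gives 2% in this assay; the number for compound 1 lies within the usual scatter of it, while the number for compound 2 lies beyond it. No two of these three differ in only one place, so no single-change step can be read from the measured set.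

Compound 4 `CC1=C(C(=O)CC(C)C)C(c2ccco2)NC(=O)N1` differs from compound 3 in one place: isobutyl in place of cyclopropyl on a carbonyl carbon. The shared core is otherwise unchanged. Nothing in the measured set speaks to the exchange of this small ring for a short chain at the carbonyl, so the expectation rests on compound 3 alone. Because compound 3 gives 2%, a small number, the expected step is a number 3 percentage points higher from compound 3 to compound 4 (within the scatter), which is taken to lie within the scatter rather than beyond it, with no direction firmly indicated. Compound 4 is therefore estimated at 5% in this assay, with a range from -5% to 20%.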

Compound 4, a percentage reported as inhibition, at one concentration (the size of the read-out at that concentration, not a potency): 16%
Compound 4: middle estimate off by 11 percentage points, on the low side, and the stated range covers the measured number.
By their numbers in this assay, from the lowest: compounds 3, 1, 4 and 2 (each within the scatter of the next, the first and the last beyond it).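

Among these compounds, the carbonyl substituent is the first place where a single change can be read: in this assay, isobutyl in place of cyclopropyl on a carbonyl carbon gives a number 14 percentage points higher from compound 3 to compound 4 (beyond the scatter) and shows that the read-out responds to what sits at this position. This rests on one pair and one exchange, in which the three-membered ring leaves and a larger open chain enters, so the loss of the ring cannot be separated from the gain in heavy atoms. The measurements shown contain nothing that accounts for the step.

The compounds shown leave open whether a ring-free group of the size of cyclopropyl, such as an n-propyl chain, would sit with compound 3 or compound 4, and whether a longer chain, a cyclohexyl ring, an amine or a carboxylic acid at this carbonyl carbon would carry the number further or bring it back. They also leave open whether the same exchange gives a similar step on a shared core carrying a different group elsewhere, and, with readings at a single concentration, how the step would appear as a potency.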